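The source may hold more compounds than are shown below. What is called first, only, known or untested is meant among the compounds shown, and "the series" means these compounds.

Working notes on a small set of chloropurine-type compounds carrying the same chloromethylbenzyl substituent on a ring nitrogen, all tested in a functional assay on OVCAR-5 cells (Homo sapiens) for cytotoxicity, read by sulforhodamine B assay, with a stated time of 48 h; a lower number here means a stronger inhibitor of growth, a higher number a weaker inhibitor of growth.

Compound 1 `ClCc1cccc(Cn2cnc3ncnc(Cl)c32)c1` gives 20000 nM in this assay. Compound 2 `ClCc1cccc(Cn2cnc3c(Cl)ncnc32)c1` has the same atoms joined differently; in this assay compound 2 gives 4360 nM. The difference between the two cores is not broken down here. Compound 3 `ClCc1cccc(Cn2cnc3c(Cl)nc(Cl)nc32)c1` is compound 2 with one added group, (chloro in place of hydrogen on an aromatic carbon), and in this assay compound 3 gives 20400 nM. The measured step is a 4.7-fold higher number from compound 2 to compound 3 (0.67 log units; beyond the scatter). Compound 1 and compound 3 sit within the usual scatter of each other, so no order between them is claimed.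

Compound 4 `ClCc1cccc(Cn2cnc3nc(Cl)nc(Cl)c32)c1` has not yet been measured. It is compound 1 with one added group, (chloro in place of hydrogen on an aromatic carbon). The place line of this change is word for word the same as for the change from compound 2 to compound 3, so this is the same change, seen here for the second time among these compounds. For the measured compounds named here, the only guide to its effect is the single measured step, a 4.7-fold higher number from compound 2 to compound 3 (0.67 log units; beyond the scatter), which weakened growth inhibition. Assuming the step carries over, the expected step is a 3.5-fold higher number from compound 1 to compound 4 (0.54 log units; beyond the scatter), resting on that one earlier step and on the value of compound 1, 20000 nM. Compound 4 is accordingly expected to give about 70000 nM in this assay, with a plausible range from 25000 nM to 200000 nM, and with a real chance that a cytotoxicity run of this kind reports only a limit at the top of its concentration range.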

Compound 4, concentration for total growth inhibition: 3230 nM
Estimate against measurement, compound 4: 22-fold (1.34 log units) above; the measured number lies below the stated range.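

In this assay, chloro in place of hydrogen on an aromatic carbon gives a 6.2-fold lower number from compound 1 to compound 4 (0.79 log units; beyond the scatter), so on the core of compound 1 the added group goes with stronger growth inhibition, the opposite direction to the step on the core of compound 2. For the compounds shown here, the change therefore does not carry over between these two cores, and a step measured on one of them gives no safe guide to the other: the same change on two cores in this assay, a 4.7-fold higher number (0.67 log units; beyond the scatter) from compound 2 to compound 3 and a 6.2-fold lower number (0.79 log units; beyond the scatter) from compound 1 to compound 4, 29-fold (1.46 log units) apart, beyond the scatter of two such steps This shows only that the core decides the direction of this change in this one cell assay; with a single step on each core, it does not show which feature of the cores is responsible, nor how the change would behave on any third core.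

Open, from the compounds shown here alone, is whether an amine or a methoxy group on the same aromatic carbon, between two ring nitrogen atoms, would split between the two cores in the same way as chloro. Also open, going by these compounds, is whether the split persists when the chloromethyl group on the benzyl ring gives way to a hydroxymethyl group or a longer chain.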